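A few compounds are considered here, and "the series" means these few. Any claim that something is new, unique, unknown or untested is made for them only; others in the source may bear on it.

Measured so far:
compound 1 `COc1cc(N2C(=O)CC2c2ccc(SC)cc2)cc(OC)c1OC` gives 108 nM
compound 2 `COc1ccc(C2C(O)C(=O)N2c2cc(OC)c(OC)c(OC)c2)cc1` gives 12 nM

In a functional assay on HT-29 cells (Homo sapiens) for inhibition, read by sulforhodamine B assay, with a stated time of 72 h (a lower number here means a stronger inhibitor, a higher number a weaker inhibitor), compound 1 has the higher number of the two, making it a weaker inhibitor than compound 2, and the gap lies beyond the scatter. These two compounds differ in more than one place, so their gap does not inform the change considered here. Compound 3 (`CCSc1ccc(C2CC(=O)N2c2cc(OC)c(OC)c(OC)c2)cc1`) keeps the core of compound 1 and turns methylsulfanyl into ethylsulfanyl, with methyl in place of hydrogen on a saturated chain carbon bound to a sulfur. Within the data shown here, no measured pair shows this change, so the expectation rests on its small size alone. A slight rise in this assay is expected, but nothing beyond the scatter. The expected step is a 1.4-fold higher number from compound 1 to compound 3 (0.14 log units; within the scatter) and stays within that scatter. Compound 3 is expected at 150 nM and is estimated to fall from 50 nM to 450 nM in repeated measurements.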

Compound 3, half-maximal inhibitory concentration: 311 nM
The estimate for compound 3 lay 2.1-fold (0.32 log units) below the measured number; low and high end bracket the measured number.
By their numbers in this assay, from the lowest: compound 2; then compound 1; then compound 3.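

In this assay, turning methylsulfanyl into ethylsulfanyl gives a 2.9-fold higher number from compound 1 to compound 3 (0.46 log units; beyond the scatter), so this position responds to a single added methyl on a saturated chain carbon bound to a sulfur, and the response is toward a weaker inhibitor. Among these compounds, the step is modest and rests on this one pair, but it is the only comparison here that isolates this position, since compound 2 differs from the others in more than one place. No measurement shown here speaks to what lies behind the step.

Going by these compounds, whether the number keeps rising with a longer chain such as propylsulfanyl, or behaves differently with a branched isopropylsulfanyl, remains open. Also open, on these data alone, is whether the same methyl would produce a comparable step on the core of compound 2.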